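The source may report more compounds than this note shows. Statements on the series, on what has been measured and on what is new or still open speak of the compounds shown alone.

Measured compounds:
Compound 1 `O=C(Nc1cccc(-c2oc3cc(-c4ccc(F)cc4)ccc3c(=O)c2O)c1)c1ccc(F)cc1` gives 16000 nM in a functional assay on MDA-MB-231 cells (Homo sapiens) for antiproliferative activity, read by CCK-8 assay, with a stated time of 72 h; a lower number here means a stronger inhibitor, a higher number a weaker inhibitor.
Compound 2 `COc1ccc(C(=O)Nc2cccc(-c3oc4cc(-c5ccc(F)cc5)ccc4c(=O)c3O)c2)cc1` gives 16500 nM in this assay.
Compound 3 `O=C(Nc1cccc(-c2oc3cc(-c4ccc(F)cc4)ccc3c(=O)c2O)c1)c1ccc(Cl)cc1` gives 12800 nM in this assay.

Compound 3 has the lowest number of the three, but its gaps to compound 1 and to compound 2 are both within the usual scatter, so the three compounds cannot be told apart on these numbers. The step now followed leads from compound 3 to compound 4 `Cc1ccccc1C(=O)Nc1cccc(-c2oc3cc(-c4ccc(F)cc4)ccc3c(=O)c2O)c1`, which has not yet been measured in this assay.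

2-methylphenyl in place of 4-chlorophenyl on a carbonyl carbon

The three measured steps each exchange a single small group on an aromatic carbon of the ring attached to the carbonyl: a 1.0-fold higher number from compound 1 to compound 2 (0.01 log units; within the scatter), a 1.3-fold lower number from compound 1 to compound 3 (0.10 log units; within the scatter) and a 1.3-fold lower number from compound 2 to compound 3 (0.11 log units; within the scatter). All three stay within the scatter, so the ring on the carbonyl carbon has so far tolerated changes without moving the number. For the measured compounds named here, the present step is larger, replacing the whole 4-chlorophenyl by 2-methylphenyl, and no measured pair covers such an exchange; still, nothing in the data points to a shift in either direction. The step from compound 3 to compound 4 is therefore expected to be small, a 1.2-fold higher number from compound 3 to compound 4 (0.07 log units; within the scatter), within the scatter. Compound 4 is estimated at 15000 nM in this assay, with a range from 7000 nM to 32000 nM.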

Compound 4, half-maximal inhibitory concentration: 4910 nM
The estimate for compound 4 lay 3.1-fold (0.49 log units) above the measured number; measured number outside the range, below it.
By their numbers in this assay, from the lowest: compound 4; then compounds 3, 1 and 2 (each within the scatter of the next).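

The ring on the carbonyl carbon can shift the number after all: in this assay, 2-methylphenyl in place of 4-chlorophenyl gives a 2.6-fold lower number from compound 3 to compound 4 (0.42 log units; beyond the scatter), while the same group gives a 3.4-fold lower number from compound 2 to compound 4 (0.53 log units; beyond the scatter) in place of 4-methoxyphenyl and a 3.3-fold lower number from compound 1 to compound 4 (0.51 log units; beyond the scatter) in place of 4-fluorophenyl. The exchanges among the three earlier rings all stayed within the scatter, whereas these three modest steps all pass beyond it, so compound 4 stands apart from the other three compounds. No supporting data are available to explain this drop.

Compound 4 differs from compound 3 both in the group on the ring, methyl rather than chlorine, and in where that group sits, so the compounds shown cannot separate these two changes; 4-methylphenyl and 2-chlorophenyl on the same carbonyl carbon would be the direct tests. Also open, from the compounds shown here alone, is how far this trend extends, for example to 2-ethylphenyl, 2-methoxyphenyl or a ring carrying an amine or a carboxylic acid.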